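The compounds below may be only part of what the source reports. "The series", "measured", "known", "first", "only" and "open" are said of these compounds alone.

Of the compounds shown here, two have been measured in an assay on isolated protein for inhibition of NADPH oxidase 2 (Homo sapiens), read by chemiluminescence, in the presence of a further agent that is not named here; a lower number here means a stronger inhibitor, a higher number a weaker inhibitor. Compound 1 `CCN(CC)c1ccc(/C=C2\C(=O)N(c3ccccc3)C(=S)N2C)c(OC)c1` gives 1470 nM, and compound 2 `COc1cc(N(C)CCCO)ccc1/C=C1\C(=O)N(c2ccccc2)C(=S)N1C` gives 2790 nM; the step of a 1.9-fold higher number from compound 1 to compound 2 (0.28 log units; within the scatter) is within the scatter, so on the numbers shown the two stand together rather than apart. Compound 3 `CCN(CC)c1ccc(/C=C2\C(=O)N(c3ccccc3)C(=S)N2C)c(O)c1` differs from compound 1 by hydrogen in place of methyl on an oxygen on an aromatic ring, which read one bond further out is a methoxy becoming a hydroxy. Among the compounds with values here, no measured step touches this oxygen; the single measured step, a 1.9-fold higher number from compound 1 to compound 2 (0.28 log units; within the scatter), changes the amine on the aromatic ring and is itself within the scatter. There is therefore no basis in this assay for a step beyond the scatter in either direction for the exchange of methyl for hydrogen, and a number close to that of compound 1 is expected. Compound 3 is estimated at 1800 nM, with a range of 700 nM to 4500 nM, a step of a 1.2-fold higher number from compound 1 to compound 3 (0.09 log units; within the scatter) that is expected to stay within the scatter.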

Compound 3, half-maximal inhibitory concentration: 910 nM
Compound 3: middle estimate off by 2.0-fold (0.30 log units), on the high side; measured number inside the range.
By their numbers in this assay, from the lowest: compounds 3, 1 and 2 (each within the scatter of the next, the first and the last beyond it).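

In this assay, within the data shown here, the exchange of methoxy to hydroxy gives a 1.6-fold lower number from compound 1 to compound 3 (0.21 log units; within the scatter), the first measured step at this oxygen on an aromatic ring. The methyl on this oxygen can therefore be replaced by hydrogen without a step beyond the scatter, and compound 1 and compound 3 cannot be put in order on these numbers. No measured information is available here to explain this result.

Whether this tolerance extends beyond hydrogen remains open, as the compounds shown include no ethyl, no longer chain and no chain ending in an amine or a carboxylic acid on this oxygen. Also open, as far as these compounds go, is how the hydroxy behaves with an amine other than diethylamino on the aromatic carbon, such as (3-hydroxypropyl)(methyl)amino.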